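Tert-Butoxycarbonyl in Place of an Oxadiazole Ring

This account rests on a few compounds, and the source may have more. Where it says the series, first, only, none or still open, it means among the compounds named here.

Of the compounds shown here, three on the shared core have been measured in a functional assay on MIA PaCa-2 cells (Homo sapiens) for inhibition, read by MTT assay, with a stated time of 3 days; a lower number here means a stronger inhibitor, a higher number a weaker inhibitor. Compound 1 `CCOC(=O)C1CCCCN1S(=O)(=O)c1ccc(S(=O)(=O)N(CC)CC)cc1` reaches only the limit of the assay, > 3000 nM, and gives no number. For the measured compounds named here, compound 2 `CCN(CC)S(=O)(=O)c1ccc(S(=O)(=O)N2CCC[C@@H](C(=O)N3CCN(c4nc(C)no4)CC3)C2)cc1` gives 200 nM, and compound 3 `CCN(CC)S(=O)(=O)c1ccc(S(=O)(=O)N2CCC[C@@H](C(=O)N3CCN(c4nnc(C(C)C)o4)CC3)C2)cc1` gives 1000 nM, the highest of the two numbers, with compound 2 the nearest; the one change between them, a 5.0-fold higher number from compound 2 to compound 3 (0.70 log units; beyond the scatter), is the only step on record. Compound 4 `CCN(CC)S(=O)(=O)c1ccc(S(=O)(=O)N2CCC[C@@H](C(=O)N3CCN(C(=O)OC(C)(C)C)CC3)C2)cc1` differs from compound 3 in the same position: tert-butoxycarbonyl in place of 5-isopropyl-1,3,4-oxadiazol-2-yl on an amine nitrogen in a ring. Going by the values given here, no measured step exchanges an aromatic group for an acyclic one on that ring nitrogen, so the record bears on the new change only loosely. The swap of one oxadiazole for another already moved the number from compound 2 to compound 3 by a modest amount, and a second, larger departure from compound 2 is expected to leave compound 4 no stronger than compound 3 in this assay, with an expected step of a 2.0-fold higher number from compound 3 to compound 4 (0.30 log units; within the scatter). Compound 4 is therefore estimated at 2000 nM, expected between 500 nM and 8000 nM.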

Compound 4, half-maximal inhibitory concentration: 10 nM
Beside the measured number, compound 4's estimate is 200-fold (2.30 log units) above it, and the stated range ends above it.
By their numbers in this assay, from the lowest: compound 4; then compound 2; then compound 3. At a limit, above all of these: compound 1.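

The two oxadiazole compounds had shown only a modest spread at this amine nitrogen in a ring, which gave no sign of how far the number in this assay could move with the group placed there. The change to tert-butoxycarbonyl gives a 100-fold lower number from compound 3 to compound 4 (2.00 log units; beyond the scatter) and a 20-fold lower number from compound 2 to compound 4 (1.30 log units; beyond the scatter), so the position responds far more strongly than the earlier step suggested. A five-membered aromatic ring is therefore not needed on this nitrogen for a low number, since the group without a ring stands lowest of the three compared here.

The compounds shown leave open whether an acetyl group, a urea or the free secondary amine on this nitrogen would keep such a low number, and whether the step depends on the tert-butyl part or on the carbonyl. Nothing shown gives a cause for the size of these steps.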